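The source may report more compounds than this note shows. Statements on the series, on what has been measured and on what is new or still open speak of the compounds shown alone.

Compound 2, `COc1cc(N2C(N)=C(C#N)C(c3c(OC)ccc4ccccc34)C3=C2CC(C)(C)CC3=O)cc(OC)c1OC`, belongs to a small group sharing one core, alongside compound 1, `COc1cc(N2C(N)=C(C#N)C(/C=C/c3ccccc3)C3=C2CC(C)(C)CC3=O)cc(OC)c1OC`, and compound 3, `COc1cc(N2C(N)=C(C#N)C(c3c(O)ccc4ccccc34)C3=C2CC(C)(C)CC3=O)cc(OC)c1OC`. In a functional assay on Ehrlich cells (Mus musculus) for cytotoxicity (on this read-out lower numbers stand for stronger inhibition and higher numbers for weaker inhibition), compound 2 gives "not active" (no number reported), so no single number places it on the scale. Compound 1 is in the same position: in this assay compound 1 gives "not active" (no number reported). Only compound 3 carries a number, and in this assay compound 3 gives 143000 nM, a very weak result. Compound 2 thus stands among the entries without a number, with one further entry beside it in that state.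

The unmeasured compound 4, `COc1cc(N2C(N)=C(C#N)C(c3cccc([N+](=O)[O-])c3)C3=C2CC(C)(C)CC3=O)cc(OC)c1OC`, differs from compound 2 in one place: 3-nitrophenyl in place of 2-methoxynaphthalen-1-yl on a saturated ring carbon. Going by the values given here, no step between measured compounds with a number at both ends exists here, so the size of the change cannot be read from the group; the expectation is at best a step that stays within the very weak region where compound 3 sits, with no direction that can be called beyond the scatter. Compound 4 is expected to give about 150000 nM in this assay, within a range from 40000 nM to 600000 nM.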

Compound 4, half-maximal inhibitory concentration: "not active" (no number reported)
No number was reported for compound 4; there is nothing to compare the estimate with.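

Going by these compounds alone, compound 2 and compound 4 are both reported as not active in this assay with no number, and no step between them can be read. Nothing shown offers an explanation for this result. The compounds shown leave open how 3-nitrophenyl and 2-methoxynaphthalen-1-yl compare on this scale.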